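Amide chain variation and cell toxicity, compounds 1 to 4

The source may hold more compounds than are shown below. What is called first, only, known or untested is meant among the compounds shown, and "the series" means these compounds.

Measured so far in a functional assay on WI-38 VA13 cells (Homo sapiens) for cytotoxicity; on this read-out lower numbers stand for an effect already at smaller amounts and higher numbers for an effect only at larger amounts of compound:
compound 1 `CCCC(=O)Nc1nc2ccc(NC(=O)c3c(Cl)cccc3Cl)cc2s1` — 0.01 ug/mL
compound 2 `CC(C)CC(=O)Nc1nc2ccc(NC(=O)c3c(Cl)cccc3Cl)cc2s1` — 0.012 ug/mL
compound 3 `CCCCCCCC(=O)Nc1nc2ccc(NC(=O)c3c(Cl)cccc3Cl)cc2s1` — 0.18 ug/mL

Compound 3 gives the highest number of the three; the gaps an 18-fold higher number from compound 1 to compound 3 (1.26 log units; beyond the scatter) and a 15-fold higher number from compound 2 to compound 3 (1.18 log units; beyond the scatter) both lie beyond the scatter, while a 1.2-fold higher number from compound 1 to compound 2 (0.08 log units; within the scatter) stays within it. In words, lengthening the chain on the carbonyl carbon raises the number substantially, whereas a methyl branch on the chain does not move it.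

Compound 4 `COC(=O)Nc1nc2ccc(NC(=O)c3c(Cl)cccc3Cl)cc2s1` differs from compound 3 by methoxy in place of heptyl on a carbonyl carbon, i.e. (heptylcarbonyl)amino becomes (methoxycarbonyl)amino. The shrinking of the chain runs the steps from compound 1 and compound 2 to compound 3 in reverse; both were large, so a large drop in this assay is expected, back toward the values of compound 1 and compound 2. For the measured compounds named here, no compound with an oxygen on that carbonyl carbon has been measured, so the range is kept wide. Compound 4 is expected at 0.02 ug/mL, between 0.005 ug/mL and 0.1 ug/mL, an estimated step of a 9.0-fold lower number from compound 3 to compound 4 (0.95 log units; beyond the scatter).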

Compound 4, half-maximal effective concentration: 0.0095 ug/mL
Compound 4: middle estimate off by 2.1-fold (0.32 log units), on the high side, and the stated range covers the measured number.
By their numbers in this assay, from the lowest: compounds 4, 1 and 2 (each within the scatter of the next); then compound 3.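

In this assay methoxy on the carbonyl carbon cannot be told apart from the short chains, since a 1.1-fold lower number from compound 1 to compound 4 (0.02 log units; within the scatter) and a 1.3-fold lower number from compound 2 to compound 4 (0.10 log units; within the scatter) both stay within the scatter. Against heptyl the picture differs, with a 19-fold lower number from compound 3 to compound 4 (1.28 log units; beyond the scatter), so among the four groups on this carbonyl carbon only heptyl stands apart, and swapping a chain for methoxy shows no separate shift of its own. Nothing measured here accounts for the gap between heptyl and the other three groups.

Where between propyl and heptyl the number begins to rise remains open, as does whether a longer group joined through oxygen, such as heptyloxy, would read like heptyl or like methoxy. The compounds shown also leave open how an amine on that carbonyl carbon would read.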